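The source may hold more compounds than are shown below. What is called first, only, known or untested is meant among the compounds shown, and "the series" means these compounds.

Measured compounds in an assay on isolated protein with Bile acid receptor (Homo sapiens) as the target; a higher number here means that more compound is needed for the effect, a lower number that less compound is needed:
- compound 1 `COC(=O)/C=C/c1cccc(N(Cc2ccc(-c3ccc(F)c(F)c3)cc2)C(=O)C2CCCCC2)c1`: 72 nM
- compound 2 `COC(=O)/C=C/c1cccc(N(Cc2ccc(Br)cc2)C(=O)C2CCCCC2)c1`: > 1000 nM; this is a limit of the assay, not a number
- compound 3 `COC(=O)/C=C/c1cccc(N(Cc2ccc(/C=C/c3cccc(Cl)c3)cc2)C(=O)C2CCCCC2)c1`: 165 nM

Among the two actual numbers, compound 3 has the higher one; the nearest is compound 1, with a 2.3-fold higher number from compound 1 to compound 3 (0.36 log units; beyond the scatter) between them. The remaining value sits at a limit (the limit of > 1000 nM in this assay, at which 1 of the 3 values shown sits).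

Compound 4 `COC(=O)/C=C/c1cccc(N(Cc2ccc(-c3ccc(OC(F)(F)F)cc3)cc2)C(=O)C2CCCCC2)c1` differs from compound 3 in one place: 4-(trifluoromethoxy)phenyl in place of 2-(3-chlorophenyl)ethenyl on an aromatic carbon.

For the measured compounds named here, two measured steps bear on this change. From compound 1 to compound 3 the biaryl was exchanged for the styryl group and gave a 2.3-fold higher number from compound 1 to compound 3 (0.36 log units; beyond the scatter), a modest rise. From compound 2 to compound 3 the bromo was replaced by the styryl group and gave an at least 6.0-fold lower number from compound 2 to compound 3 (0.78 log units; beyond the scatter), so a large aromatic substituent here is clearly favored over the small halogen. Compound 4 returns to a biaryl of the kind seen in compound 1, so a modest fall, roughly undoing the step from compound 1 to compound 3, is expected; the step from compound 3 to compound 4 is estimated at a 2.1-fold lower number from compound 3 to compound 4 (0.31 log units; beyond the scatter).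

Compound 4 is therefore expected to give about 80 nM, within 35 nM to 200 nM.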

Compound 4, half-maximal effective concentration: 264 nM
Beside the measured number, compound 4's estimate is 3.3-fold (0.52 log units) below it, outside the stated range (above it).
By their numbers in this assay, from the lowest: compound 1; then compounds 3 and 4 (each within the scatter of the next). At a limit, above all of these: compound 2.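

In this assay, a biaryl at this aromatic carbon does not by itself fix the value: a 3.7-fold higher number from compound 1 to compound 4 (0.56 log units; beyond the scatter), a modest rise that separates 3,4-difluorophenyl from 4-(trifluoromethoxy)phenyl, whereas a 1.6-fold higher number from compound 3 to compound 4 (0.20 log units; within the scatter), so 4-(trifluoromethoxy)phenyl and 2-(3-chlorophenyl)ethenyl cannot be told apart here. The advantage of a large aromatic substituent over bromo holds for this new group as well, with an at least 3.7-fold lower number from compound 2 to compound 4 (0.57 log units; beyond the scatter), so the position now shows sensitivity to the substituents on the outer ring as well as to the presence of that ring. The value of compound 2 is a limit of the assay and not a number, so that step gives only a bound: the limit of > 1000 nM in this assay, at which 1 of the 4 values shown sits.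

The compounds shown leave open which feature of the outer ring accounts for the step between the two biaryls, as a single fluorine or a lone trifluoromethoxy group at another ring position would be needed to separate these substituents. On these data alone, it also remains open how this position responds to an amine or a carboxylic acid on the outer ring.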